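Adding a phenyl to a methylamino substituent

The source may report more compounds than this note shows. Statements on the series, on what has been measured and on what is new or still open speak of the compounds shown alone.

Compound 1 `COc1cc(OC)n2cc(-c3ccc(N)cc3)nc2n1`: in a functional assay on HT-29 cells (Homo sapiens) for antiproliferative activity, read by MTT assay, with a stated time of 72 h (on this read-out higher numbers stand for weaker inhibition of growth and lower numbers for stronger inhibition of growth), compound 1 gives > 100000 nM, which is a limit of the assay.
Compound 2 `CNc1ccc(-c2cn3c(OC)cc(OC)nc3n2)cc1`: in this assay compound 2 gives > 100000 nM, which is a limit of the assay.

Compound 2 therefore stands at the limit, without a number of its own. Both measured values sit at the limit of > 100000 nM in this assay, at which 2 of the 2 values shown sit, so the step from compound 1 to compound 2 (a step that the two limits leave unreadable from compound 1 to compound 2) cannot be read. Compound 3 `COc1cc(OC)n2cc(-c3ccc(NCc4ccccc4)cc3)nc2n1` differs from compound 2 by phenyl in place of hydrogen on a saturated chain carbon bound to a nitrogen on an aromatic ring. Going by the values given here, no measured step bears on this change, so no direction can be taken from the measured pair. The step from compound 2 to compound 3 is therefore estimated as a step that the limit leaves unreadable from compound 2 to compound 3. Compound 3 is expected near 150000 nM, between 30000 nM and 1000000 nM, most likely reported again only as a limit.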

Compound 3, concentration for 50% growth inhibition: > 100000 nM
Compound 3: only a limit was reported; the forecaster's own chance of this, stated with the estimate: 75%; the middle value does not contradict the limit.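

No new step can be read among compound 1, compound 2 and compound 3, because all three are reported only as a limit: the limit of > 100000 nM in this assay, at which 3 of the 3 values shown sit.

As far as these compounds go, whether benzylamino and methylamino differ at all in their effect on growth stays open.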